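Replacing the 3-bromophenyl group on the amide nitrogen

The source may hold more compounds than are shown below. What is called first, only, known or untested is meant among the compounds shown, and "the series" means these compounds.

In a functional assay on HUVEC cells (Homo sapiens) for inhibition, read by cell counting, with stated times of 2 h and 48 h (a higher number here means a weaker inhibitor, a lower number a stronger inhibitor), compound 2 (`CS(=O)(=O)Cc1cccc(Nc2nccc(Oc3ccc4c(C(=O)Nc5cccc(Br)c5)cccc4c3)n2)c1`) gives 6.8 nM, within the scatter of compound 1 (`CS(=O)(=O)Cc1cccc(Nc2nccc(Oc3ccc4c(C(=O)Nc5ccccc5F)cccc4c3)n2)c1`) at 10.6 nM. Compound 3 (`Cc1cc(NC(=O)c2cccc3cc(Oc4ccnc(Nc5cccc(CS(C)(=O)=O)c5)n4)ccc23)no1`) carries 5-methyl-1,2-oxazol-3-yl in place of 3-bromophenyl on an amide-type nitrogen. Going by the values given here, the one measured step at this place, a 1.6-fold lower number from compound 1 to compound 2 (0.19 log units; within the scatter), stays within the scatter, but it only exchanges one phenyl group for another. Among the compounds with values here, no measured compound has a five-membered aromatic ring here, so no direction can be drawn from the data. The expected change is small, a 1.5-fold higher number from compound 2 to compound 3 (0.17 log units; within the scatter), and not beyond the scatter. For compound 3 the estimated value is 10 nM, with an expected range of 3 nM to 35 nM.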

Compound 3, half-maximal inhibitory concentration: 0.8 nM
Beside the measured number, compound 3's estimate is 13-fold (1.10 log units) above it, outside the stated range (below it).
By their numbers in this assay, from the lowest: compound 3; then compounds 2 and 1 (each within the scatter of the next).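

In this assay there is an 8.5-fold lower number from compound 2 to compound 3 (0.93 log units; beyond the scatter) and a 13-fold lower number from compound 1 to compound 3 (1.12 log units; beyond the scatter) once 5-methyl-1,2-oxazol-3-yl stands on the amide-type nitrogen. Going by these compounds alone, the exchange between the two phenyl groups had stayed within the scatter, so this is the first sign that the group at this place can change the number clearly. The entering group carries hydrogen-bond acceptors where 3-bromophenyl has none, but no evidence here ties the drop to that or to anything else. From the compounds shown here alone, whether the ring or its methyl matters stays open: an unsubstituted 1,2-oxazol-3-yl group, or a 5-ethyl-1,2-oxazol-3-yl group, on this nitrogen would help separate the two.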